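The source may hold more compounds than are shown below. What is called first, only, known or untested is meant among the compounds shown, and "the series" means these compounds.

Compound 1 `Cc1ccc(-c2cn3nc(Cc4ccc(Cl)cc4)sc3n2)cc1`, compound 2 `Cc1ccc(-c2nc3sc(Cc4ccc(Cl)cc4)nn3c2C=O)cc1` and compound 3 `N#CSc1c(-c2ccc(Br)cc2)nc2sc(Cc3ccc(Cl)cc3)nn12` have been measured. In a functional assay on L1210 cells (Mus musculus) for cytotoxicity, with a stated time of 48 h (on this read-out higher numbers stand for weaker inhibition and lower numbers for stronger inhibition), compound 1 gives > 250000 nM, which is a limit of the assay. Compound 2 gives 23000 nM and compound 3 gives 81000 nM, so compound 3 has the higher of the two numbers, with compound 2 the lower. Compound 4 `Cc1ccc(-c2nc3sc(Cc4ccc(Cl)cc4)nn3c2SC#N)cc1` differs from compound 3 by methyl in place of bromo on an aromatic carbon. Among the measured compounds shown here, the only measured step, an at least 10-fold lower number from compound 1 to compound 2 (1.03 log units; beyond the scatter), concerns a different position and does not bear on this change. With no guide, the step of a 1.4-fold lower number from compound 3 to compound 4 (0.13 log units; within the scatter) is expected to stay within the scatter. Compound 4 is therefore estimated at 60000 nM, between 15000 nM and 250000 nM.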

Compound 4, half-maximal inhibitory concentration: 32000 nM
Estimate against measurement, compound 4: 1.9-fold (0.27 log units) above; the range from low to high includes it.
By their numbers in this assay, from the lowest: compounds 2 and 4 (each within the scatter of the next); then compound 3. At a limit, above all of these: compound 1.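

In this assay, changing 4-bromophenyl to 4-methylphenyl has a measurable effect, with a 2.5-fold lower number from compound 3 to compound 4 (0.40 log units; beyond the scatter). On the aromatic carbon that carries them, cyanosulfanyl and formyl are not told apart, with a 1.4-fold higher number from compound 2 to compound 4 (0.14 log units; within the scatter). Cyanosulfanyl in place of hydrogen gives an at least 7.8-fold lower number from compound 1 to compound 4 (0.89 log units; beyond the scatter), a step that rests on a limit of the assay: the limit of > 250000 nM in this assay, at which 1 of the 4 values shown sits.

The compounds shown leave open how 4-methoxyphenyl or 4-aminophenyl would compare with 4-methylphenyl. They also leave open whether an amine or a carboxylic acid on that aromatic carbon would match cyanosulfanyl and formyl.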